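The source may hold more compounds than are shown below. What is called first, only, known or untested is meant among the compounds shown, and "the series" means these compounds.

Measured so far:
compound 1, `Cc1ccccc1[C@H]1COC(N)=N1`: 78%
compound 2, `NC1=N[C@@H](c2ccccc2)CO1`: 104%

In a functional assay on HEK293 cells for agonist activity at trace amine-associated receptor 1 (Homo sapiens), read by cAMP accumulation, with a stated time of 30 min (on this read-out higher numbers stand for larger maximal responses and lower numbers for smaller maximal responses), compound 2 gives 104%, the higher of the two numbers recorded, while compound 1 gives 78%. Within the data shown here, the only step yet measured, a number 26 percentage points higher from compound 1 to compound 2 (beyond the scatter), came with hydrogen in place of methyl on an aromatic carbon.

Compound 3, `NC1=N[C@@H](c2cccc(F)c2)CO1`, is the next case. It differs from compound 2 as follows: fluoro in place of hydrogen on an aromatic carbon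

The measured step removed a methyl from the ring of the shared core; the change into compound 3 instead adds a fluorine to a ring that already carries only hydrogens besides the core. Among the measured compounds shown here, no step among the measured compounds involves a fluoro group, so the measured data give no direct bearing on its size or direction. The account therefore rests on compound 2 alone, and compound 3 is expected to stay close to it, with a number 4 percentage points lower from compound 2 to compound 3 (within the scatter) falling within the scatter. The estimate for compound 3 in this assay is 100%, between 82% and 115%, pending the measurement.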

Compound 3, largest response reached (Emax), in percent of the reference or control that the assay uses: 83%
Compound 3: middle estimate off by 17 percentage points, on the high side; the range from low to high includes it.
By their numbers in this assay, from the lowest: compounds 1 and 3 (each within the scatter of the next); then compound 2.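

In this assay, a fluoro group on an aromatic carbon, meta to a group of 6 heavy atoms, brought a number 21 percentage points lower from compound 2 to compound 3 (beyond the scatter). Among these compounds, a single fluorine atom at this position is therefore enough to change the maximal response beyond the scatter, which the earlier compounds could not show, as none of them carried a fluoro group. Alongside the earlier step, a number 26 percentage points higher from compound 1 to compound 2 (beyond the scatter), this gives two cases in which the compound with only hydrogens on the ring, compound 2 at 104%, gives the larger response, with no listed compound going against that, though two cases with different groups establish no general rule.

The compounds shown leave open whether a chlorine atom, a methoxy group or an amine at this same position would give a similar response, and whether a fluoro group on another carbon of the ring would match the step seen here. Nothing available bears on why the response fell with the fluoro group.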